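Aryl substituent swap on the shared core: chloro for nitro

The source may report more compounds than this note shows. Statements on the series, on what has been measured and on what is new or still open speak of the compounds shown alone.

Two compounds of the series carry measured values in a functional assay on the whole organism (Tail) for activation, with Mus musculus as the target, with a stated time of 1 min; a higher number here means that more compound is needed for the effect, a lower number that less compound is needed. Compound 1 `O=C1CN(/N=C/c2ccc(-c3cccc(C(F)(F)F)c3)o2)C(=O)N1` gives 184 mg/kg in this assay. Compound 2 `O=C1NC(=O)N(/N=C/c2ccc(-c3ccc([N+](=O)[O-])cc3)o2)C1O`, which bears a hydroxyl on its core and a nitro on the distal ring, reaches no number in this assay; its result is a limit of > 1000 mg/kg. Thus compound 2 stands at the edge of what this assay can report, and only one of the two values is a proper number, as the limit of > 1000 mg/kg in this assay, at which 1 of the 2 values shown sits, shows.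

Compound 3 `O=C1NC(=O)N(/N=C/c2ccc(-c3ccc(Cl)cc3)o2)C1O` has not yet been run in this assay. Its structure departs from compound 2 in one place: chloro in place of nitro on an aromatic carbon. Going by the values given here, no measured pair differs in one place, so the size of this step cannot be read from the data. The expectation is that compound 3 needs less compound than compound 2, since compound 1 with its own aryl group gives 184 mg/kg, an estimated step of an at least 2.0-fold lower number from compound 2 to compound 3 (0.30 log units; that floor lies within the scatter). Compound 3 is therefore expected to give about 500 mg/kg in this assay, within a range from 150 mg/kg to 1500 mg/kg.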

Compound 3, dose for half-maximal effect: > 1000 mg/kg
Compound 3: no number, only a limit (the forecaster's own chance of this, stated with the estimate: 40%); at least 2.0-fold (0.30 log units) between middle value and limit.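

Compound 2 and compound 3 both end at a limit in this assay, so no step from compound 2 to compound 3 can be read: the limit of > 1000 mg/kg in this assay, at which 2 of the 3 values shown sit.

From the compounds shown here alone, what stays open is whether chloro in place of nitro on an aromatic carbon changes the dose for half-maximal effect on this shared core at all, and in which direction.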